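Trifluoromethyl for methyl on the benzyl oxime ether

The compounds below may be only part of what the source reports. "The series", "measured", "known", "first", "only" and "open" are said of these compounds alone.

Among the measured compounds shown here, compound 1 `Cc1ccc(CO/N=C2/C(c3c[nH]c4ccc(Br)cc34)=Nc3ccc(Br)cc32)cc1` and compound 2 `FC(F)(F)c1ccc(CO/N=C2/C(c3c[nH]c4ccccc34)=Nc3ccccc32)cc1` are the two compounds measured so far. In a functional assay on A549 cells (Homo sapiens) for cytotoxicity, read by MTT assay, with a stated time of 2 days (on this read-out lower numbers stand for stronger inhibition and higher numbers for weaker inhibition), compound 1 gives 13300 nM, and in this assay compound 2 gives 21900 nM. The two numbers lie within the scatter of each other, so neither stands apart. Compound 3 `FC(F)(F)c1ccc(CO/N=C2/C(c3c[nH]c4ccc(Br)cc34)=Nc3ccc(Br)cc32)cc1` is not yet measured. It differs from compound 1 by trifluoromethyl in place of methyl on an aromatic carbon. For the measured compounds named here, no single-change step between measured compounds shows what this exchange does here, so for compound 3 a step of a 1.3-fold higher number from compound 1 to compound 3 (0.11 log units; within the scatter) is expected, not beyond the scatter in either direction. Compound 3 is estimated at 17000 nM in this assay, within a range of 7000 nM to 45000 nM.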

Compound 3, half-maximal inhibitory concentration: 8450 nM
Compound 3: the middle estimate sits 2.0-fold (0.30 log units) above what was measured, and the stated range covers the measured number.
By their numbers in this assay, from the lowest: compounds 3, 1 and 2 (each within the scatter of the next, the first and the last beyond it).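

Among the compounds shown here, the first single-change reading at this position in this assay is a 1.6-fold lower number from compound 1 to compound 3 (0.20 log units; within the scatter), so on the core of compound 1, trifluoromethyl in place of methyl on this aromatic carbon, para to a large group, gives no step beyond the scatter. The exchange from 4-methylbenzyl to 4-(trifluoromethyl)benzyl is therefore tolerated in this read-out, with four heavy atoms entering where one leaves. No measurement at hand bears on this result. Open, on these data alone, are an amine, a carboxylic acid or a longer chain at this place, and how the same exchange reads on the core of compound 2.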